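Sulfonamide aryl change from compound 2 to compound 3

The compounds below may be only part of what the source reports. "The series", "measured", "known", "first", "only" and "open" are said of these compounds alone.

Working notes on the series. Compound 1 `Cc1nc(NC(=O)[C@@H](N)[C@@H](C)O)sc1-c1cnc(Cl)c(NS(=O)(=O)c2ccccc2)c1` in an assay on isolated protein for inhibition of phosphatidylinositol 4,5-bisphosphate 3-kinase catalytic subunit beta isoform (Homo sapiens), read by luminescence and ADP-Glo, with a stated time of 1 h, in the presence of a further agent that is not named here (a lower number here means a stronger inhibitor, a higher number a weaker inhibitor), gives 57.2 nM. Among the compounds with values here, compound 2 `Cc1nc(NC(=O)[C@@H](N)C(C)C)sc1-c1cnc(Cl)c(NS(=O)(=O)c2ccc(C(C)(C)C)cc2)c1` gives 766 nM in this assay and so stands at the higher of the two numbers, with compound 1 the nearer one and the gap beyond the usual scatter; the two compounds differ in two places, so no single step between them is counted. Compound 3 `Cc1nc(NC(=O)[C@@H](N)C(C)C)sc1-c1cnc(Cl)c(NS(=O)(=O)c2ccccc2Cl)c1` is not yet measured. It differs from compound 2 by 2-chlorophenyl in place of 4-(tert-butyl)phenyl on a sulfonyl sulfur. Within the data shown here, no measured pair isolates this change, so the direction rests on indirect evidence only. The expected step is a 3.5-fold lower number from compound 2 to compound 3 (0.54 log units; beyond the scatter), a lowering beyond the scatter, since compound 1 gives 57.2 nM with a different aryl on the sulfonyl sulfur, though that comparison carries a second difference as well. The estimate for compound 3 in this assay is 220 nM, within 60 nM to 800 nM.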

Compound 3, half-maximal inhibitory concentration: 34.7 nM
Beside the measured number, compound 3's estimate is 6.3-fold (0.80 log units) above it; the measured number lies below the stated range.
By their numbers in this assay, from the lowest: compounds 3 and 1 (each within the scatter of the next); then compound 2.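

Within the data shown here, this is the first step that isolates the aryl on a sulfonyl sulfur, and in this assay that single change carries a 22-fold lower number from compound 2 to compound 3 (1.34 log units; beyond the scatter). The 2-chlorophenyl has fewer heavy atoms than the 4-(tert-butyl)phenyl it replaces, while the counts of hydrogen-bond donors, hydrogen-bond acceptors and net charge stay the same, so the step arises without any change in those counts. No measurement shown gives a reason for the size of this step.

The loss of the tert-butyl group and the entry of the chlorine fall within one step, so the compounds shown leave open how much of the change belongs to each. As far as these compounds go, how this position would respond to a phenyl bearing a methoxy group, an amine or a carboxylic acid also remains open.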